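The source may hold more compounds than are shown below. What is called first, only, known or untested is meant among the compounds shown, and "the series" means these compounds.

Measured in a functional assay on A2780 cells (Homo sapiens) for antiproliferative activity, read by fluorescence, with a stated time of 72 h; a lower number here means a stronger inhibitor, a higher number a weaker inhibitor:

compound 1 `CN1CCC(C(=O)N2Cc3c(NC(=O)c4ccsc4)n[nH]c3C2(C)C)CC1` — 140 nM
compound 2 `CC(C)CC(=O)Nc1n[nH]c2c1CN(C(=O)C1CCN(C3CC3)CC1)C2(C)C` — 320 nM
compound 3 `CN1CCN(C(=O)N2Cc3c(NC(=O)c4ccc(F)cc4)n[nH]c3C2(C)C)CC1` — 180 nM

Compound 1 gives the lowest of the three numbers in this assay. Its gap to compound 3 lies within the scatter, so no order between those two can be read; its gap to compound 2 lies beyond the scatter. Compound 4 `CN1CCC(C(=O)N2Cc3c(NC(=O)c4ccc(C(F)(F)F)cc4)n[nH]c3C2(C)C)CC1` is not yet measured. It differs from compound 1 in one place: 4-(trifluoromethyl)phenyl in place of thiophen-3-yl on a carbonyl carbon. Among the compounds with values here, no step between two measured compounds isolates this change, so the expectation rests on compound 1 alone. The step of a 1.4-fold higher number from compound 1 to compound 4 (0.15 log units; within the scatter) is expected to be small, with no direction beyond the scatter. Compound 4 is estimated at 200 nM, with a range from 80 nM to 500 nM.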

Compound 4, half-maximal inhibitory concentration: 60 nM
Compound 4: middle estimate off by 3.3-fold (0.52 log units), on the high side; the whole stated range lies above it.
By their numbers in this assay, from the lowest: compound 4; then compounds 1, 3 and 2 (each within the scatter of the next, the first and the last beyond it).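

Within the data shown here, replacing thiophen-3-yl with 4-(trifluoromethyl)phenyl on a carbonyl carbon gives a 2.3-fold lower number from compound 1 to compound 4 (0.37 log units; beyond the scatter) in this assay, the first single-place step. This position therefore accepts the larger aromatic group, and the number falls rather than rises. No measurement at hand speaks to the cause of this step.

As far as these compounds go, whether the step belongs to the six-membered ring or to its trifluoromethyl remains open. Plain phenyl, or a nitrile or carboxylic acid in place of the trifluoromethyl, would separate the two.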